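A few compounds are considered here, and "the series" means these few. Any claim that something is new, unique, unknown or untested is made for them only; others in the source may bear on it.

Series values in a functional assay on DU-145 cells (Homo sapiens) for inhibition, read by trypan blue exclusion, with a stated time of 96 h; on this read-out lower numbers stand for stronger inhibition of growth and higher numbers for weaker inhibition of growth:

- compound 1 `CCOc1cc(/C=C(\C(=O)c2ccc(Cl)cc2)S(=O)(=O)Cc2ccc(Cl)cc2)ccc1O` gives 10000 nM
- compound 2 `Cc1ccsc1/C=C(\C(=O)c1ccc(Cl)cc1)S(=O)(=O)Cc1ccc(Cl)cc1` gives 25000 nM

Of these two compounds, compound 2 carries the higher number, 25000 nM, and so shows the weaker inhibition of growth. The next structure is compound 3 `CSc1ccc(/C=C(\C(=O)c2ccc(Cl)cc2)S(=O)(=O)Cc2ccc(Cl)cc2)cc1`, not yet measured. It has 4-(methylsulfanyl)phenyl in place of 3-methylthiophen-2-yl on a double-bonded chain carbon bound to a double-bonded chain carbon.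

For the measured compounds named here, one measured step bears on this change: a 2.5-fold higher number from compound 1 to compound 2 (0.40 log units; beyond the scatter). That step put the 3-methylthiophen-2-yl group in place of 3-ethoxy-4-hydroxyphenyl, so the present change runs the other way, from the same group back to a six-membered aromatic ring. Going by the values given here, the analogy is only partial, since the groups on the two six-membered rings differ, and no measured compound carries 4-(methylsulfanyl)phenyl. A modest shift toward a lower number is therefore expected in this assay, and the uncertainty is wide.

The expected change is a 2.1-fold lower number from compound 2 to compound 3 (0.32 log units; beyond the scatter).

For compound 3 the estimated value is 12000 nM.

The expected range for compound 3 runs from 3000 nM to 40000 nM.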

Compound 3, concentration for 50% growth inhibition: 10000 nM
Compound 3: middle estimate off by 1.2-fold (0.08 log units), on the high side; low and high end bracket the measured number.
By their numbers in this assay, from the lowest: compounds 1 and 3 (each within the scatter of the next); then compound 2.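

In this assay, going from the 3-methylthiophen-2-yl group to the 4-(methylsulfanyl)phenyl group gives a 2.5-fold lower number from compound 2 to compound 3 (0.40 log units; beyond the scatter), so the step seen earlier with a different six-membered aromatic ring now appears with a second one, and compound 2 stands as the weakest of the three. The two six-membered aromatic rings read alike, with no change at the digits printed from compound 1 to compound 3 (within the scatter), although their substituents differ. The ethoxy and hydroxy groups of compound 1 are therefore not required for this level of growth inhibition, since compound 3 carries neither. No measurement at hand accounts for these differences.

The change from compound 2 to compound 3 alters ring size and substituent together, so the compounds shown cannot separate the share of each, and an unsubstituted phenyl or thiophene ring would be needed to do so. From the compounds shown here alone, it also remains open whether a dimethylamino group or a carboxylic acid on the ring at this place would move the number away from the level shared by compound 1 and compound 3.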